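A few compounds are considered here, and "the series" means these few. Any claim that something is new, unique, unknown or untested is made for them only; others in the source may bear on it.

The measured compounds: compound 1 `Cc1ccc(C)c(-c2nc(CN3CCC(C(=O)NCCCN4C[C@H](C)C[C@H](C)C4)CC3)c(C)o2)c1`, with "not determined" (no result reported) in a physicochemical assay for permeability, using PAMPA; a higher number here means that the compound crosses the layer faster, a lower number that the compound crosses the layer more slowly; compound 2 `Cc1ccccc1-c1nc(CN2CCC(C(=O)NCCCCN3C[C@H](C)C[C@H](C)C3)CC2)c(C)o1`, which gives 288 10^-6 cm/s in this assay.

Compound 1 therefore stands on no number of its own in this assay; only compound 2 offers a reading. The step from compound 1 leads to compound 3 `COc1cccc(Cl)c1-c1nc(CN2CCC(C(=O)NCCCN3C[C@H](C)C[C@H](C)C3)CC2)c(C)o1`, where the change is 2-chloro-6-methoxyphenyl in place of 2,5-dimethylphenyl on an aromatic carbon. Going by the values given here, with no measured step to lean on, the author expects compound 3 to remain in the range set by compound 2, with no shift beyond the usual scatter. Compound 3 is estimated at 200 10^-6 cm/s, between 80 10^-6 cm/s and 400 10^-6 cm/s.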

Compound 3, apparent permeability: 51 10^-6 cm/s
For compound 3 the middle estimate is 3.9-fold (0.59 log units) above the measured one, outside the stated range (below it).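

In this assay, going by these compounds alone, compound 1 offers no number, so no step from compound 1 to compound 3 can be read. The compounds shown leave open what 2-chloro-6-methoxyphenyl in place of 2,5-dimethylphenyl does to this read-out. No evidence given here bears on the result of compound 3.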